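High Extraction Maintained Across a Small Amide Series

The compounds below may be only part of what the source reports. "The series", "measured", "known", "first", "only" and "open" are said of these compounds alone.

Measured so far:
- compound 1 `CS(=O)(=O)N1CCC[C@H](c2csc(-c3ccccc3NC(=O)c3nc(Cl)c[nH]3)n2)C1`: 0.91
- compound 2 `CS(=O)(=O)N1CCC[C@H](c2csc(-c3ccccc3NC(=O)c3nc4ccccc4[nH]3)n2)C1`: 0.86
- compound 3 `CCS(=O)(=O)N1CCC[C@H](c2csc(-c3ccccc3NC(=O)c3ncc[nH]3)n2)C1`: 0.95

In an ADME assay on microsomes from liver (Homo sapiens) (a lower number here means that the liver removes a smaller share, a higher number that the liver removes a larger share of the compound in one pass), compound 3 gives 0.95, a value within the scatter of both compound 1 and compound 2. Going by the values given here, the only single-place step measured, a number 0.050 lower from compound 1 to compound 2 (within the scatter), concerns the amide side and does not touch the ring nitrogen. Compound 4 `COC(=O)N1CCC[C@H](c2csc(-c3ccccc3NC(=O)c3ncc[nH]3)n2)C1` differs from compound 3 by methoxycarbonyl in place of ethylsulfonyl on an amine nitrogen in a ring. Among the compounds with values here, no measured step bears on this position, so nothing beyond the scatter is expected: the step from compound 3 to compound 4 is estimated at a number 0.020 lower from compound 3 to compound 4 (within the scatter). Compound 4 is therefore expected to give about 0.93 in this assay, within a range of 0.85 to 0.99.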

Compound 4, hepatic extraction ratio: 0.75
Beside the measured number, compound 4's estimate is 0.18 above it, outside the stated range (below it).
By their numbers in this assay, from the lowest: compound 4; then compounds 2, 1 and 3 (each within the scatter of the next).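

With methoxycarbonyl in place of ethylsulfonyl on the amine nitrogen in the ring, the read-out in this assay comes out a number 0.20 lower from compound 3 to compound 4 (beyond the scatter). Going by these compounds alone, the only earlier step lay on the amide side, so this is the first sign that the group on this nitrogen can move the hepatic extraction ratio by more than the scatter. Nothing available here accounts for the change. Open, as far as these compounds go, is how an acetyl group, a propylsulfonyl group or a free amine at this nitrogen would compare, and whether the step would hold with the amide groups of compound 1 and compound 2.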